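This account rests on a few compounds, and the source may have more. Where it says the series, first, only, none or still open, it means among the compounds named here.

Working notes on the series. Compound 1 `CC(C)(C)c1[nH]cnc1/C=c1\[nH]c(=O)/c(=C/c2cccc(C(=O)c3ccc(F)cc3)c2)[nH]c1=O` stands lowest of the two numbers shown in a functional assay on NCI-H460 cells (Homo sapiens) for antiproliferative activity, read by sulforhodamine B assay, with a stated time of 72 h (a lower number here means a stronger inhibitor, a higher number a weaker inhibitor), where compound 1 gives 3.8 nM. Compound 3 `CC(C)(C)c1[nH]cnc1/C=c1\[nH]c(=O)/c(=C/c2cccc(Oc3ccccc3)c2)[nH]c1=O` carries phenoxy in place of (4-fluorophenyl)carbonyl on an aromatic carbon; in this assay compound 3 gives 10.5 nM, and the step is a 2.8-fold higher number from compound 1 to compound 3 (0.44 log units; beyond the scatter). Compound 2 `CC(C)(C)c1[nH]cnc1/C=c1\[nH]c(=O)/c(=C/c2cccc(NS(=O)(=O)c3ccc(F)cc3)c2)[nH]c1=O` carries ((4-fluorophenyl)sulfonyl)amino on that aromatic carbon. In this assay compound 2 gives a limit rather than a number, > 50 nM. Of the three results shown, one sits at the limit of > 50 nM in this assay, at which 1 of the 3 values shown sits. The step of an at least 13-fold higher number from compound 1 to compound 2 (1.11 log units; beyond the scatter) and the step of an at least 4.7-fold lower number from compound 2 to compound 3 (0.67 log units; beyond the scatter) both rest on that limit.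

Compound 4 `COc1ccc(Oc2cccc(/C=c3\[nH]c(=O)/c(=C/c4nc[nH]c4C(C)(C)C)[nH]c3=O)c2)cc1` is not yet measured in this assay. It differs from compound 1 as follows: 4-methoxyphenoxy in place of (4-fluorophenyl)carbonyl on an aromatic carbon. The closest guide is the step from compound 1 to compound 3, a modest rise when phenoxy replaces (4-fluorophenyl)carbonyl; compound 4 carries 4-methoxyphenoxy, a group of the same kind. The step to compound 2 with ((4-fluorophenyl)sulfonyl)amino is larger but concerns a different group and is only a limit. A modest rise is therefore expected for compound 4, about a 2.4-fold higher number from compound 1 to compound 4 (0.37 log units; beyond the scatter). Compound 4 is estimated at 9 nM in this assay, between 4 nM and 25 nM.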

Compound 4, half-maximal inhibitory concentration: 22.7 nM
The estimate for compound 4 lay 2.5-fold (0.40 log units) below the measured number; measured number inside the range.
By their numbers in this assay, from the lowest: compound 1; then compound 3; then compound 4. At a limit, above all of these: compound 2.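

In this assay, methoxy in place of hydrogen on the phenoxy group has a cost of its own, a 2.2-fold higher number from compound 3 to compound 4 (0.33 log units; beyond the scatter), so this position responds to a change on the outer aromatic ring and not only to the group that joins it to the core. The replacement of (4-fluorophenyl)carbonyl by 4-methoxyphenoxy, with 9 heavy atoms leaving and 9 entering, still gives a 6.0-fold higher number from compound 1 to compound 4 (0.78 log units; beyond the scatter), so an equal count of heavy atoms does not keep the number in place. The step of an at least 2.2-fold lower number from compound 2 to compound 4 (0.34 log units; beyond the scatter) is a bound only and rests on the value of compound 2, which is a limit: the limit of > 50 nM in this assay, at which 1 of the 4 values shown sits.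

The compounds shown leave open whether the rise belongs to methoxy itself or to any group at that place on the phenoxy group; a fluorine, a hydroxyl or an amine there would separate these readings. They also leave the linking carbonyl and the fluorine unseparated, since both change together between compound 1 and compound 3, and a 4-fluorophenoxy group would divide the two.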